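The source may report more compounds than this note shows. Statements on the series, on what has been measured and on what is new or still open speak of the compounds shown alone.

In a functional assay on AGS cells (Homo sapiens) for inhibition, read by MTT assay, with a stated time of 72 h (on this read-out lower numbers stand for stronger inhibition and higher numbers for weaker inhibition), compound 1 `Cc1ccc(N2CCCC2)c(C(=O)Nc2ccc(CNC(=O)OCc3cccnc3)cc2)c1` gives 24700 nM and compound 2 `COc1ccc(N2CCCC2)c(C(=O)Nc2ccc(CNC(=O)OCc3cccnc3)cc2)c1` gives 25600 nM. Among the measured compounds shown here, these are the only two numbers, and they lie within the scatter of each other. Compound 3 `Cc1cccc(C(=O)Nc2ccc(CNC(=O)OCc3cccnc3)cc2)c1N1CCCC1` reads > 100000 nM, which is a limit of the assay.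

Compound 4 `O=C(NCc1ccc(NC(=O)c2cc(Br)ccc2N2CCCC2)cc1)OCc1cccnc1` comes from compound 1 by one change: bromo in place of methyl on an aromatic carbon. For the measured compounds named here, the single measured step that replaces this methyl is a 1.0-fold higher number from compound 1 to compound 2 (0.02 log units; within the scatter), with methoxy entering on the aromatic carbon. On that step alone, no change beyond the scatter is expected in this assay. Compound 4 is estimated at 20000 nM, with an expected range of 8000 nM to 50000 nM. This estimate means an expected 1.2-fold lower number from compound 1 to compound 4 (0.09 log units; within the scatter).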

Compound 4, half-maximal inhibitory concentration: > 100000 nM
Compound 4 was reported as a limit (the forecaster's own chance of this, stated with the estimate: 8%); middle value at least 5.0-fold (0.69 log units) away from the limit.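

In this assay, the position para to a pyrrolidin-1-yl group proves sensitive to the group it carries: bromo gives an at least 4.0-fold higher number from compound 1 to compound 4 (0.60 log units; beyond the scatter), and likewise an at least 3.9-fold higher number from compound 2 to compound 4 (0.59 log units; beyond the scatter). Methyl and methoxy alone had shown no such difference here, so tolerance at this position does not extend to every small group. The value of compound 4 is a limit and not a number, so both steps give only a minimum size: the limit of > 100000 nM in this assay, at which 2 of the 4 values shown sit.

Open, on these data alone, is whether chloro or an amine at this position would read like methyl and methoxy or like bromo.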